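Replacing the Proline Acid of Compound 1 with Glycine

The source may report more compounds than this note shows. Statements on the series, on what has been measured and on what is new or still open speak of the compounds shown alone.

Measured compounds:
compound 1 `O=C(O)[C@@H]1CCCN1C(=O)CN(c1nc(Cl)nc2[nH]cnc12)C1CC1` with 34.9%
compound 2 `CC(C)[C@H](NC(=O)CN(c1ncnc2c1ncn2C1CCCCO1)C1CC1)C(=O)OCc1ccccc1` with 34.9%
compound 3 `CC(C)C[C@H](NC(=O)CN(c1ncnc2c1ncn2C1CCCCO1)C1CC1)C(=O)OCc1ccccc1` with 34.2%

Three compounds share an acylated cyclopropylamino side chain on a purine core and have been tested in a functional assay on the whole organism (Tail, strain ICR) with Mus musculus as the target, in the tail flick test, with a stated time of 60 min, at a dose of 25 umol/kg by the oral route; a higher number here means a stronger effect of the compound at the dose given, a lower number a weaker effect. Compound 1 stands level with compound 2 at the digits reported, and the two together are the highest of the three numbers; the gap to compound 3 is within the scatter. Among the measured compounds shown here, the only measured step between compounds differing in one place is a number 0.7 percentage points lower from compound 2 to compound 3 (within the scatter), and it does not touch the part of the molecule that changes here.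

Compound 4 `O=C(O)CNC(=O)CN(c1nc(Cl)nc2[nH]cnc12)C1CC1` is the next compound to be measured. It differs from compound 1 as follows: (carboxymethyl)amino in place of 2-carboxypyrrolidin-1-yl on a carbonyl carbon. For the measured compounds named here, no measured pair shows this kind of exchange, so nothing beyond the general size of the scatter can be drawn from the data. The writer therefore expects no step beyond the scatter, and estimates for compound 4 a value of 33% in this assay, within a range of 18% to 48%. This estimate implies a step of a number 1.9 percentage points lower from compound 1 to compound 4 (within the scatter), which is expected to lie within the usual scatter.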

Compound 4, a percentage reported as activity, at one dose (the size of the read-out at that dose, not a potency): 38.9%
The estimate for compound 4 lay 5.9 percentage points below the measured number; measured number inside the range.
By their numbers in this assay, from the lowest: compounds 3, 1, 2 and 4 (each within the scatter of the next).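

Among the compounds shown here, until now no measured pair had touched this position, and in this assay the exchange on a carbonyl carbon of 2-carboxypyrrolidin-1-yl for (carboxymethyl)amino gives a number 4 percentage points higher from compound 1 to compound 4 (within the scatter). The step shows that, at this single dose, the five-membered non-aromatic ring and the defined stereocentre of the group in compound 1 can both be lost without the read-out leaving the scatter, while the carboxylic acid is kept on both sides of the pair; the same holds for the smaller group with its added hydrogen-bond donor, so neither feature can be singled out as mattering here. Nothing available explains why the read-out holds across this change.

What the compounds shown leave open is whether the carboxylic acid itself counts at this place, as a primary amide or a methyl ester in its stead would show. Equally open, from the compounds shown here alone, is whether a longer chain in place of the carboxymethyl, such as a carboxypropyl chain, or a methyl group on the chain carbon of compound 4 would move the number beyond the scatter.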